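The source may report more compounds than this note shows. Statements on the series, on what has been measured and on what is new or still open speak of the compounds shown alone.

Compound 1 `COc1ccc(-c2cn(C/C=C3\OC(=O)C(OCc4ccccc4)=C3OCc3ccccc3)nn2)cc1`: > 100000 nM
Compound 2 `C[Si](C)(C)c1cn(C[C@H](O)[C@H]2OC(=O)C(OCc3ccccc3)=C2OCc2ccccc2)nn1`: 56000 nM
Compound 3 `O=C1O/C(=C\Cn2cc(-c3cc(C(F)(F)F)cc(C(F)(F)F)c3)nn2)C(OCc2ccccc2)=C1OCc1ccccc1`: > 100000 nM

Of the compounds shown here, three sharing the same core have been measured in a functional assay on SW-620 cells (Homo sapiens) for antiproliferative activity, read by MTT assay, with a stated time of 72 h; on this read-out lower numbers stand for stronger inhibition and higher numbers for weaker inhibition. Compound 1 reaches only a limit of the assay, giving > 100000 nM. Compound 3 likewise reaches only a limit, giving > 100000 nM. Among the measured compounds shown here, compound 2 is the single member of the set with a measured number, giving 56000 nM in this assay. It therefore stands alone as the one point from which any comparison can start, since the other two results sit at the limit of > 100000 nM in this assay, at which 2 of the 3 values shown sit.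

For the measured compounds named here, no pair of these measured compounds differs in a single place, so no measured step is available to guide a prediction. The next compound, compound 4 `CCCCc1cn(C[C@H](O)[C@H]2OC(=O)C(OCc3ccccc3)=C2OCc2ccccc2)nn1`, differs from compound 2 in one place: a group of 4 heavy atoms (4 carbon; no ring) in place of a group of 4 heavy atoms (3 carbon, 1 silicon; no ring), on an aromatic carbon. Both groups carry the same count of heavy atoms and neither adds a donor or an acceptor. With nothing in the measured set to suggest that such a swap moves the read-out, compound 4 is expected to sit close to compound 2, with an estimated step of a 1.2-fold higher number from compound 2 to compound 4 (0.06 log units; within the scatter) that does not exceed the usual scatter. Compound 4 is thus estimated at 65000 nM in this assay, within a range from 25000 nM to 170000 nM.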

Compound 4, half-maximal inhibitory concentration: 47500 nM
Compound 4: middle estimate off by 1.4-fold (0.14 log units), on the high side; the range from low to high includes it.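

Among the compounds shown here, exchanging the silicon-bearing group for butyl on this aromatic carbon gives the first measured step in this assay, a 1.2-fold lower number from compound 2 to compound 4 (0.07 log units; within the scatter). At this place on the five-membered aromatic ring with 3 nitrogen, an all-carbon group of the same heavy-atom count therefore leaves the read-out within the scatter, and no difference between the silicon-bearing group and butyl can be read here. The earlier compounds could not show this, as no two of them differed in one place, and two of the results offered only a limit: the limit of > 100000 nM in this assay, at which 2 of the 4 values shown sit.

From the compounds shown here alone, whether a shorter chain, a longer chain such as octyl, or a chain ending in an amine or a carboxylic acid would move the read-out at this aromatic carbon remains open. Also open is whether the read-out would change if the two benzyl ethers on the shared core gave way to free hydroxyl groups, as the compounds shown all carry those ethers.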